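Methylating the Amide Nitrogen of Compound 1

A few compounds are considered here, and "the series" means these few. Any claim that something is new, unique, unknown or untested is made for them only; others in the source may bear on it.

Measured so far:
Compound 1, `CN(C)C(=O)CCNC(=O)c1cc(-c2ccc(F)cc2)no1`, in an ADME assay on microsomes from liver (Homo sapiens) for metabolic stability, with a stated time of 0.5 h, tested at 0.5 mg/mL (on this read-out higher numbers stand for a more stable compound and lower numbers for a less stable compound), gives 87%.
Compound 2, `CN(C)C(=O)CCNC(=O)c1cc(-c2cccc(F)c2)no1`, in this assay gives > 100%, which is a limit of the assay and not a number.

Going by the values given here, compound 1 thus holds the only value that is an actual number; the other value shown is the limit of > 100% in this assay, at which 1 of the 2 values shown sits. Among the compounds with values here, the single measured step, a number at least 13 percentage points higher from compound 1 to compound 2 (beyond the scatter), concerns the fluorophenyl group only. Compound 3, `CN(C)C(=O)CCN(C)C(=O)c1cc(-c2ccc(F)cc2)no1`, differs from compound 1 by methyl in place of hydrogen on an amide-type nitrogen. Within the data shown here, no measured step touches an amide-type nitrogen, so the measured data give no guide for this change. Compound 3 is therefore expected to show a number 2 percentage points lower from compound 1 to compound 3 (within the scatter), a step within the scatter, with an estimate of 85% ranging from 60% to 100%.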

Compound 3, percent of the compound remaining: 98%
Compound 3: middle estimate off by 13 percentage points, on the low side; the measured number falls inside the stated range.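

Methyl in place of hydrogen on the amide-type nitrogen gives, in this assay, a number 11 percentage points higher from compound 1 to compound 3 (beyond the scatter). Going by these compounds alone, this is the first measured step at that nitrogen, and it shows that a place other than the fluorophenyl group can also move this read-out, with the amide hydrogen not required for the value of compound 3. Compound 2 holds a limit and not a number, so its step cannot be ranked in size against this one: the limit of > 100% in this assay, at which 1 of the 3 values shown sits.

On these data alone, whether an ethyl group or a longer chain on this nitrogen would match methyl remains open. So does what methyl on this nitrogen would do alongside a 3-fluorophenyl group in a single compound.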